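A few compounds are considered here, and "the series" means these few. Any claim that something is new, unique, unknown or untested is made for them only; others in the source may bear on it.

Two compounds have a number in a functional assay on HTB-54 cells (Homo sapiens) for cytotoxicity, read by MTT assay, with a stated time of 72 h (on this read-out higher numbers stand for weaker inhibition of growth and lower numbers for stronger inhibition of growth), so far. Among the measured compounds shown here, compound 1 `CCCOC(=O)Nc1ccc([Se]C#N)cc1` gives 51900 nM there, and compound 2 `CCCCCCOC(=O)Nc1ccc([Se][Se]c2ccc(NC(=O)OCCCCCC)cc2)cc1` gives 54300 nM; the two numbers lie within the usual scatter of each other, so compound 1 stands level with its one neighbour rather than apart from it. Compound 3 `CCOC(=O)Nc1ccc([Se]C#N)cc1` differs from compound 1 in one place: hydrogen in place of methyl on a saturated chain carbon, two bonds along the chain from an oxygen next to a carbonyl group. For the measured compounds named here, no such step has been measured here. Shortening the chain by one carbon at a point away from the core of compound 1 is expected to leave this assay essentially unmoved, with the step of a 1.1-fold higher number from compound 1 to compound 3 (0.03 log units; within the scatter) judged to be within the scatter. Compound 3 is therefore estimated at 55000 nM, with a range from 25000 nM to 120000 nM.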

Compound 3, concentration for total growth inhibition: 49300 nM
For compound 3 the middle estimate is 1.1-fold (0.05 log units) above the measured one, and the stated range covers the measured number.
By their numbers in this assay, from the lowest: compounds 3, 1 and 2 (each within the scatter of the next).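

In this assay, hydrogen in place of methyl on a saturated chain carbon, two bonds along the chain from an oxygen next to a carbonyl group, gives a 1.1-fold lower number from compound 1 to compound 3 (0.02 log units; within the scatter) and stays within the scatter. This first measured step at the position shows that, for this one pair, propoxy to ethoxy does not separate the two compounds. Nothing available speaks to the reason for this result. Going by these compounds, whether a longer chain or a terminal amine in this place would move the number remains open, and one step cannot show whether the same change behaves alike elsewhere.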